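A few compounds are considered here, and "the series" means these few. Any claim that something is new, unique, unknown or untested is made for them only; others in the source may bear on it.

For the measured compounds named here, in a functional assay on A549 cells (Homo sapiens) for antiproliferative activity, read by MTT assay, with a stated time of 48 h (a lower number here means a stronger inhibitor, a higher number a weaker inhibitor), compound 2 `CN1CCN(CCCn2c(N)c(-c3nc4ccccc4[nH]3)c3nc(C#N)c(C#N)nc32)CC1` gives 5750 nM, the only true number available so far. Compound 1 `CCn1c(N)c(-c2nc3ccccc3[nH]2)c2nc(C#N)c(C#N)nc21` stands at > 50000 nM, which is a limit of the assay. Going by the values given here, the single measured step, an at least 8.6-fold lower number from compound 1 to compound 2 (0.93 log units; beyond the scatter), came with (4-methylpiperazin-1-yl)methyl in place of hydrogen on a saturated chain carbon, two bonds along the chain from an aromatic nitrogen. Compound 3 `CCCCn1c(N)c(-c2nc3ccccc3[nH]2)c2nc(C#N)c(C#N)nc21` gives up the basic-free comparison of neither: its change is methyl in place of 4-methylpiperazin-1-yl on a saturated chain carbon, three bonds along the chain from an aromatic nitrogen, so that 3-(4-methylpiperazin-1-yl)propyl goes to butyl and the chain again ends without a ring, as the ethyl of compound 1 does. Among the compounds with values here, only that one step bears on this change, and it points to a sizeable move towards a higher number in this assay, beyond the scatter. The expected change is a 5.2-fold higher number from compound 2 to compound 3 (0.72 log units; beyond the scatter). Compound 3 is estimated at 30000 nM, with an expected range of 12000 nM to 50000 nM.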

Compound 3, half-maximal inhibitory concentration: > 50000 nM
Compound 3: a limit, no number; the forecaster's own chance of this, stated with the estimate: 45%; middle value at least 1.6-fold (0.22 log units) away from the limit.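

Going from the 3-(4-methylpiperazin-1-yl)propyl chain to butyl gives, in this assay, an at least 8.6-fold higher number from compound 2 to compound 3 (0.93 log units; beyond the scatter). For the compounds shown here, the earlier step had changed the chain from ethyl while also adding the 4-methylpiperazin-1-yl, whereas this one removes that group and leaves a plain chain, which still gives no measured number, so in these compounds the only measured number goes with the 4-methylpiperazin-1-yl end. The step from compound 1 to compound 3 cannot be read, so ethyl and butyl cannot be ranked: the limit of > 50000 nM in this assay, at which 2 of the 3 values shown sit.

On these data alone, it remains open whether another amine at the chain end, such as morpholine, dimethylamino or a piperazine without the methyl, would give a measurable number. As far as these compounds go, it is also open how a shorter or longer chain carrying the 4-methylpiperazin-1-yl would compare with compound 2.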